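This account rests on a few compounds, and the source may have more. Where it says the series, first, only, none or still open, it means among the compounds named here.

Compounds measured in an assay on Sf9 cells for inhibition of histone deacetylase 11 (Homo sapiens), read by fluorescence, tested at 0.5 uM; a lower number here means less inhibition, a higher number more inhibition at the concentration tested (going by the name of the read-out):
- compound 1, `O=C(NO)c1cccc(-c2cn([C@H]3C[C@H](CO)N(CCCc4ccccc4)C3)nn2)c1`: < 10%
- compound 2, `O=C(/C=C/c1cn([C@@H]2C[C@H](CO)N(CCCc3ccccc3)C2)nn1)NO`: 12%
- compound 3, `O=C(/C=C/c1cn([C@@H]2C[C@@H](CO)N(CCCc3ccccc3)C2)nn1)NO`: 13%

The value of compound 1 in this assay is a limit of the assay and not a number. Among the two numbers, compound 3 has the higher one, with compound 2 nearest to it; the step of a number 1 percentage points higher from compound 2 to compound 3 (within the scatter) lies within the scatter, and the two compounds differ only in the drawn configuration at one saturated ring carbon.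

The unmeasured compound is compound 4, `O=C(/C=C/c1cn([C@H]2C[C@H](CO)N(CCCc3ccccc3)C2)nn1)NO`. Against compound 3 the change is the two compounds have the same atoms and bonds and differ only in configuration as drawn: 2 of 3 stereo elements differ; a stereocentre at a saturated ring carbon is drawn R in compound 3 and S in compound 4; a stereocentre at a saturated ring carbon is drawn S in compound 3 and R in compound 4. For the measured compounds named here, only one measured step bears on this kind of change: a number 1 percentage points higher from compound 2 to compound 3 (within the scatter), which is within the scatter. Going by the values given here, no other pair differs only in configuration, and compound 1 offers no numerical comparison because its result is the limit (the limit of < 10% in this assay, at which 1 of the 3 values shown sits). On the evidence of the fact that compounds 2 and 3 differ only in the configuration as drawn and the small step it produced, the two configurational inversions in compound 4 are expected to give a step of no change at the digits printed from compound 3 to compound 4 (within the scatter) in this assay, that is, none beyond the scatter in either direction. Compound 4 is therefore estimated at 13%, within a range from 5% to 22%.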

Compound 4, a percentage reported as inhibition, at one concentration (the size of the read-out at that concentration, not a potency): 16%
Beside the measured number, compound 4's estimate is 3 percentage points below it; measured number inside the range.
By their numbers in this assay, from the lowest: compounds 2, 3 and 4 (each within the scatter of the next). At a limit, below all of these: compound 1.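

In this assay, changing both saturated ring carbons together gives a number 3 percentage points higher from compound 3 to compound 4 (within the scatter), and changing one of them gives a number 4 percentage points higher from compound 2 to compound 4 (within the scatter), so these new configurational comparisons, including the first in which two stereocentres differ, add no step beyond the scatter to the one seen before. Placing 2-(hydroxycarbamoyl)ethenyl instead of 3-(hydroxycarbamoyl)phenyl on an aromatic carbon gives a number at least 6 percentage points higher from compound 1 to compound 4 (that floor lies within the scatter), which for the first time links the two groups through a printed step, though it too does not establish a change beyond the scatter. The result for compound 1, < 10%, is a limit of the assay.

The compounds shown leave open whether the remaining combination of configurations at the two ring carbons, or a carboxylic acid or an amine in place of the hydroxymethyl group, would move the read-out in this assay beyond the scatter. Because the read-out comes from a single concentration, it also leaves open how these compounds would compare in potency.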